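The source may report more compounds than this note shows. Statements on the series, on what has been measured and on what is new or still open speak of the compounds shown alone.

Working notes on the series.

In a functional assay (Homo sapiens) for inhibition (on this read-out lower numbers stand for stronger inhibition and higher numbers for weaker inhibition), compound 1 `CCCCOc1ccccc1C(=O)/C=C/c1cc(OC)cc(OC)c1` gives 13000 nM. Compound 2 `COc1cc(/C=C/C(=O)c2ccccc2[N+](=O)[O-])cc(OC)c1` differs from compound 1 in one place, (nitro in place of butoxy on an aromatic carbon), and in this assay compound 2 gives 3700 nM. The step made by this change is a 3.5-fold lower number from compound 1 to compound 2 (0.55 log units; beyond the scatter).

Compound 3 `CCCCOc1cccc(C(=O)/C=C/c2ccc(OC)cc2OC)c1` has the same atoms as compound 1 joined differently; the difference between the two cores is not broken down here. In this assay compound 3 gives 65000 nM, the highest number among the three measured compounds, with every step to the others beyond the scatter.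

Compound 4 `COc1ccc(/C=C/C(=O)c2cccc([N+](=O)[O-])c2)c(OC)c1` is not yet measured. From compound 3 it differs by nitro in place of butoxy on an aromatic carbon. In compound 2 the nitro sits ortho to a large group, while in compound 4 it sits meta to a large group, so this is the same kind of change rather than the same change. The expected step is a 3.0-fold lower number from compound 3 to compound 4 (0.47 log units; beyond the scatter), set beside a 3.5-fold lower number from compound 1 to compound 2 (0.55 log units; beyond the scatter); it rests on that one measured step alone, and the different place around the change leaves the size uncertain. Compound 4 is estimated at 22000 nM in this assay, with a likely range from 8000 nM to 60000 nM.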

Compound 4, half-maximal inhibitory concentration: 18000 nM
Compound 4: middle estimate off by 1.2-fold (0.09 log units), on the high side; the measured number falls inside the stated range.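

In this assay, nitro in place of butoxy gives a 3.6-fold lower number from compound 3 to compound 4 (0.56 log units; beyond the scatter), and this step matches the one on the other core: the same change on two cores in this assay, a 3.5-fold lower number (0.55 log units; beyond the scatter) from compound 1 to compound 2 and a 3.6-fold lower number (0.56 log units; beyond the scatter) from compound 3 to compound 4, 1.0-fold (0.01 log units) apart, within the scatter of two such steps

For these two pairs, then, the size of the change carries from one core to the other, even though the surroundings of the change differ between the pairs, and the gap between the cores themselves does not alter it. Within the data shown here, this shows only that the step repeats on two cores; it does not show why it repeats, assign any property to nitro or butoxy, or establish a rule for other cores.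

On these data alone, it remains open whether an amine or a carboxylic acid in place of butoxy would also give a step of similar size on both cores. As far as these compounds go, it is also open whether the nitro step would hold on a third core, where the remaining methoxy groups are placed differently or replaced.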